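Lengthening the Ester Chain on Two Related Cores

The source may hold more compounds than are shown below. What is called first, only, known or untested is meant among the compounds shown, and "the series" means these compounds.

The study concerns four compounds that share an ester-bearing scaffold and differ in the size of the ester chain or in the core itself. Compound 1 `CCCOC(=O)C1=C(C)NC(=S)NC1c1ccoc1` and compound 2 `CC1=C(C(=O)OCC(C)C)C(c2ccoc2)NC(=S)N1` carry one core; compound 3 `CCOC(=O)C1=C(C)N(C)C(=O)NC1c1cccs1` and the not yet measured compound 4 `CCCOC(=O)C1=C(C)N(C)C(=O)NC1c1cccs1` carry another. The difference between the two cores is not broken down here.

In an assay on membranes from CHO cells for displacement of a labelled ligand from adenosine receptor A1 (Homo sapiens), read by scintillation counting, with a stated time of 60 min, tested at 1 uM (on this read-out lower numbers stand for less inhibition and higher numbers for more inhibition at the one concentration tested (going by the name of the read-out)), compound 1 gives 4%, compound 2 gives 12% and compound 3 gives 1%. From compound 1 to compound 2 the change is methyl in place of hydrogen on a saturated chain carbon bound to two saturated chain carbons, and the step it made was a number 8 percentage points higher from compound 1 to compound 2 (within the scatter). The change from compound 3 to compound 4 is methyl in place of hydrogen on a saturated chain carbon, two bonds along the chain from an oxygen next to a carbonyl group; it is the same kind of change, a methyl in place of hydrogen on a saturated chain carbon, but the place is not identical, since in the first pair the carbon is bound to two saturated chain carbons, whereas in the second it lies two bonds along the chain from an oxygen next to a carbonyl group.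

Because the earlier step of a number 8 percentage points higher from compound 1 to compound 2 (within the scatter) stayed within the scatter, and because compound 3 itself gives 1%, compound 4 is expected to show a step of a number 4 percentage points higher from compound 3 to compound 4 (within the scatter) in this assay. Compound 4 is thus estimated at 5% in this assay, expected to lie between -5% and 15%.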

Compound 4, a percentage reported as inhibition, at one concentration (the size of the read-out at that concentration, not a potency): 9%
Compound 4: middle estimate off by 4 percentage points, on the low side; the range from low to high includes it.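

In this assay, the methyl that turns the ethoxy of compound 3 into the propoxy of compound 4 gave a number 8 percentage points higher from compound 3 to compound 4 (within the scatter), and this result can be set directly beside the earlier step on the other core: the same change on two cores in this assay, a number 8 percentage points higher (within the scatter) from compound 1 to compound 2 and a number 8 percentage points higher (within the scatter) from compound 3 to compound 4, 0 percentage points apart, within the scatter of two such steps As far as these two pairs can tell, then, a methyl in place of hydrogen on a saturated chain carbon of the ester chain reads alike on both cores, and nothing here speaks against carrying the change from one core to the other. It does not show that the change does anything real on either core, as both steps stay within the scatter, the two places on the chain are not identical, and agreement between two such small steps at a single concentration says nothing about potency.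

The compounds shown leave open how a longer chain on the ester, or a carboxylic acid in its place, would read on either core. Among the compounds shown here, they also leave open what the core alone contributes, as no pair among them differs only in the core.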